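Benzofuranyl for thiophenyl: an untested analogue of compound 3

The source may report more compounds than this note shows. Statements on the series, on what has been measured and on what is new or still open speak of the compounds shown alone.

Measured values in a functional assay on CHO cells for agonist activity at Free fatty acid receptor 1 (Homo sapiens), read by FLIPR and calcium flux, tested at 100 nM; a lower number here means a weaker effect, a higher number a stronger effect of the compound at the concentration tested:
compound 1 `O=C(O)CC1COc2cc(OCc3ncc(-c4ccccc4)o3)ccc21`: 2.34%
compound 2 `O=C(O)CC1COc2cc(OCc3ncc(-c4ccccc4)s3)ccc21`: 5.26%
compound 3 `Cc1nc(-c2cccs2)sc1COc1ccc2c(c1)OCC2CC(=O)O`: 35.2%

Compound 3 stands highest of the three numbers in this assay; its nearest neighbour is compound 2, lower by a margin beyond the scatter, and compound 1 lies furthest, also lower beyond the scatter. Compound 4 `Cc1nc(-c2cc3ccccc3o2)sc1COc1ccc2c(c1)OCC2CC(=O)O` is not yet measured. It differs from compound 3 in one place: 1-benzofuran-2-yl in place of thiophen-2-yl on an aromatic carbon. Among the measured compounds shown here, no measured pair shares this change, so nothing in the data shows which way it pulls. The step from compound 3 to compound 4 in this assay is expected to be small, with a number 3.2 percentage points lower from compound 3 to compound 4 (within the scatter), in either direction and plausibly within the scatter. Compound 4 is accordingly estimated at 32%, in a range from 10% to 58%.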

Compound 4, a percentage reported as activity, at one concentration (the size of the read-out at that concentration, not a potency): 14.8%
For compound 4 the middle estimate is 17.2 percentage points above the measured one; measured number inside the range.
By their numbers in this assay, from the lowest: compounds 1, 2 and 4 (each within the scatter of the next, the first and the last beyond it); then compound 3.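

In this assay, among the compounds shown here, the only measured single change at this position gives a number 20.4 percentage points lower from compound 3 to compound 4 (beyond the scatter), so the aromatic carbon next to the ring nitrogen and next to the ring sulfur responds to the group it carries. On this one pair, 1-benzofuran-2-yl does not keep the read-out seen with thiophen-2-yl. No measured property available here bears on the reason for this step.

Still open, from the compounds shown here alone, is how furan-2-yl would read at this position, which would separate the exchange of sulfur for oxygen from the added six-membered aromatic ring of carbon only.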